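The compounds below may be only part of what the source reports. "The series", "measured", "known", "first", "only" and "open" are said of these compounds alone.

Compound 1 `COc1ccc(N2C(=O)CSC2c2sc(Cc3ccc(Cl)cc3)nc2C)cc1` is one of three analogues that share a core and differ in the ring attached to the amide nitrogen. In a functional assay on the whole organism (strain Wistar albino) for inhibition, with Rattus norvegicus as the target, read by paw edema, with stated times of 1 h and 2 h, at a dose of 40 mg/kg by the oral route (a lower number here means less inhibition, a higher number more inhibition at the dose given (going by the name of the read-out)), compound 1 gives 28.6%, the lower of the two numbers reported; compound 3 `Cc1nc(Cc2ccc(Cl)cc2)sc1C1SCC(=O)N1c1ccc(Cl)cc1` gives 40.1%, and compound 2 `Cc1nc(Cc2ccc(Cl)cc2)sc1C1SCC(=O)N1c1ccccc1` is reported as "not active" (no number reported). For the measured compounds named here, the one step between measured compounds, a number 11.5 percentage points higher from compound 1 to compound 3 (beyond the scatter), concerns a different place from the change now considered. Compound 4 `COc1ccc(N2C(=O)CSC2c2sc(-c3ccc(Cl)cc3)nc2C)cc1` differs from compound 1 as follows: 4-chlorophenyl in place of 4-chlorobenzyl on an aromatic carbon. Going by the values given here, no measured pair shows this change, so the step of a number 1.4 percentage points higher from compound 1 to compound 4 (within the scatter) is expected to lie within the scatter. For compound 4 the value is therefore estimated at 30%, between 15% and 45%.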

Compound 4, a percentage reported as inhibition, in the whole organism at one dose (the size of the read-out at that dose, not a potency): 80.7%
For compound 4 the middle estimate is 50.7 percentage points below the measured one, outside the stated range (above it).
By their numbers in this assay, from the lowest: compound 1; then compound 3; then compound 4.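

With 4-chlorophenyl in place of 4-chlorobenzyl on the aromatic carbon of the five-membered ring, this assay shows a number 52.1 percentage points higher from compound 1 to compound 4 (beyond the scatter). For the compounds shown here, the earlier compounds differed only in the ring on the amide nitrogen, so this is the first sign that this other position also has a large bearing on the read-out. Nothing given here accounts for the step.

As far as these compounds go, whether the step holds with chloro in place of methoxy on the other ring remains open. So does the outcome with an amine or a longer chain at this position.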